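The compounds below may be only part of what the source reports. "The series", "measured", "known", "first", "only" and "open" are said of these compounds alone.

Of the compounds shown here, three have been measured in a functional assay on KB cells (Homo sapiens) for inhibition; a higher number here means a weaker inhibitor, a lower number a stronger inhibitor. Compound 1 `OCCOCn1c(Cl)nc2c(Cl)c(Cl)ccc21` reaches only the limit > 100000 nM, which is a boundary of the assay and not a number. Compound 2 `OCCOCn1c(SCc2ccccc2)nc2cc(Cl)c(Cl)cc21` gives 55000 nM. Compound 3 `Nc1nc2c(Cl)cc(Cl)cc2n1COCCO` also stops at the limit > 100000 nM, again a boundary rather than a number. Compound 3 therefore stands with compound 1 at the limit of > 100000 nM in this assay, at which 2 of the 3 values shown sit, with no measured number of its own, and only compound 2 supplies one. Compound 4 `OCCOCn1c(SCc2ccccc2)nc2c(Cl)cc(Cl)cc21` differs from compound 3 in one place: benzylsulfanyl in place of amino on an aromatic carbon. For the measured compounds named here, no step between measured compounds is known, so the size of this change has no direct precedent here. Going by the values given here, the one guide is compound 2, which carries the same benzylsulfanyl group and gives 55000 nM in this assay. On that basis compound 4 is expected to improve modestly, by an estimated step of an at least 1.6-fold lower number from compound 3 to compound 4 (0.22 log units; that floor lies within the scatter) that may still leave it near the limit of this assay. The estimate for compound 4 is 60000 nM, with a range from 20000 nM to 200000 nM.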

Compound 4, half-maximal inhibitory concentration: > 100000 nM
Compound 4: only a limit was reported; the forecaster's own chance of this, stated with the estimate: 45%; middle value at least 1.6-fold (0.22 log units) from the limit.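

For the compounds shown here, compound 3 and compound 4 both stop at a limit of this assay rather than a number, so no step between them can be read. How far benzylsulfanyl in place of amino shifts inhibition stays open, with both compounds at the same boundary: the limit of > 100000 nM in this assay, at which 3 of the 4 values shown sit.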